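The source may report more compounds than this note shows. Statements on the series, on what has been measured and on what is new or still open speak of the compounds shown alone.

In a functional assay on HOS-TE85 cells (Homo sapiens) for inhibition, read by CCK-8 assay, with a stated time of 72 h (a lower number here means a stronger inhibitor, a higher number a weaker inhibitor), compound 2 `O=C(NCCCCn1cccn1)c1cccc(C2SCC(=O)N2c2cccnc2)c1` gives > 1000 nM, which is a limit of the assay and not a number. Compound 1 `COc1ccc(OC)c(N2C(=O)CSC2c2cccc(C(=O)NCCCCc3ccccc3)c2)c1` gives > 1000 nM, also a limit. Compound 3 `O=C(NCCCCc1ccccc1)c1cccc(C2SCC(=O)N2c2cccc(-c3c[nH]nn3)c2)c1`, by contrast, gives a real number, 110 nM. Compound 2 therefore stands at the limit of > 1000 nM in this assay, at which 2 of the 3 values shown sit.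

The change to compound 4 `O=C(NCCCCn1cccn1)c1cccc(C2SCC(=O)N2c2cccc(C3CC3)c2)c1` is 3-cyclopropylphenyl in place of pyridin-3-yl on an amide-type nitrogen in a ring. For the measured compounds named here, only one measured step bears on this place, an at least 9.0-fold lower number from compound 1 to compound 3 (0.95 log units; beyond the scatter), and it lies beyond the scatter. That step is only a loose guide, as it involves other groups and compounds 1 and 3 also differ from compound 2 at the far end of the molecule. It does show that changing this group can shift the number considerably. A lower number is therefore expected in this assay, probably by a smaller step, and a result still at the limit remains quite possible. The estimated change is an at least 1.6-fold lower number from compound 2 to compound 4 (0.22 log units; that floor lies within the scatter). Compound 4 is expected to give about 600 nM, with an estimated range of 120 nM to 3000 nM.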

Compound 4, half-maximal inhibitory concentration: 299 nM
Beside the measured number, compound 4's estimate is 2.0-fold (0.30 log units) above it; measured number inside the range.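

With the chain at the far end of the molecule unchanged, swapping pyridin-3-yl for 3-cyclopropylphenyl on the amide-type nitrogen in the ring moves the number in this assay: an at least 3.3-fold lower number from compound 2 to compound 4 (0.52 log units; beyond the scatter). For the compounds shown here, the only earlier step at this position came with a different chain at the far end, so this result shows that the group here also matters with the chain of compound 4. The true size of the new step remains unknown, and it may be larger than printed, because the starting point is not an exact value: the limit of > 1000 nM in this assay, at which 2 of the 4 values shown sit.

A plain phenyl group at this position would help separate the part played by the cyclopropyl group from that of losing the ring nitrogen. Going by these compounds, how a 3-aminophenyl or 3-carboxyphenyl group would behave here also remains open.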